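Swapping the Cyclohexyl Substituent on a Kinase Inhibitor Core

The compounds below may be only part of what the source reports. "The series", "measured", "known", "first", "only" and "open" are said of these compounds alone.

Compound 1, `CO[C@H]1CC[C@H](Nc2cc(NCc3cnccc3C(F)(F)F)ncc2C#N)CC1`, gives 1100 nM in an assay on isolated protein for inhibition of protein kinase C theta type (Homo sapiens), read by TR-FRET, with a stated time of 2 h; a higher number here means a weaker inhibitor, a lower number a stronger inhibitor.
Compound 2, `N#Cc1cnc(NCc2ccccc2C(F)(F)F)cc1N[C@H]1C[C@@H](C(N)=O)C1`, gives 150 nM in this assay.

Compound 1 has the higher of the two numbers: compound 2 sits well below it, and the gap between them is beyond the usual scatter of this measurement. Both share the same core, but compound 2 differs from compound 1 in more than one place, so no single change can be tied to that gap.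

Compound 3, `CC1(C)C[C@@H](Nc2cc(NCc3cnccc3C(F)(F)F)ncc2C#N)CC[C@@H]1O`, is the one to be measured. It differs from compound 1 in one place: 4-hydroxy-3,3-dimethylcyclohexyl in place of 4-methoxycyclohexyl on a nitrogen on an aromatic ring. The change keeps one six-membered ring of carbon only and adds a hydrogen-bond donor while keeping one acceptor.

For the measured compounds named here, no measured pair shows this change on its own. Compound 2, the only other point, carries an amide donor and gives 150 nM, which hints that a donor at this position may be tolerated or helpful, but that is weak evidence. A modest gain, roughly at the edge of the scatter, is expected as the step of a 1.8-fold lower number from compound 1 to compound 3 (0.26 log units; within the scatter). Compound 3 is therefore estimated at 600 nM, within a range from 200 nM to 2000 nM.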

Compound 3, half-maximal inhibitory concentration: 120 nM
Estimate against measurement, compound 3: 5.0-fold (0.70 log units) above, and the stated range ends above it.
By their numbers in this assay, from the lowest: compounds 3 and 2 (each within the scatter of the next); then compound 1.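

In this assay, 4-hydroxy-3,3-dimethylcyclohexyl in place of 4-methoxycyclohexyl gives a 9.2-fold lower number from compound 1 to compound 3 (0.96 log units; beyond the scatter), so a change at this one place, on a nitrogen on an aromatic ring, moves the number well past the usual scatter. Until now, the only gap available came from two compounds differing in more than one place, whereas this gap belongs to a single substituent swap on an otherwise unchanged structure. Nothing measured here explains why the number falls.

The swap also bundles several differences into one step: the methoxy becomes a hydroxyl, and the dimethyl groups appear on the ring, so the compounds shown cannot say which of these accounts for the step. A hydroxycyclohexyl without the dimethyl groups, a methoxycyclohexyl carrying them, or an amine in place of the hydroxyl would each be needed to pull these contributions apart, and the answer could differ from what this one pair suggests.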